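Methoxy addition on the aniline ring: clearance working notes

The source may report more compounds than this note shows. Statements on the series, on what has been measured and on what is new or still open speak of the compounds shown alone.

Measured so far:
- compound 1 `C=CC(=O)N1CC[C@H](N2C(=O)N(Cc3ccccc3)Cc3cnc(Nc4ccc(N5CCN(C)CC5)cc4OC)nc32)C1` gives 1040 mL/min/kg
- compound 2 `C=CC(=O)N1CC[C@H](N2C(=O)N(c3ccccc3)Cc3cnc(Nc4ccc(N5CCN(C)CC5)cc4)nc32)C1` gives 203 mL/min/kg

In an ADME assay on the whole organism (strain Sprague-Dawley) for pharmacokinetics, with Rattus norvegicus as the target, read by LC-MS, at a dose of 25 mg/kg by the oral route (a lower number here means slower removal, a higher number faster removal of the compound), compound 2 stands at 203 mL/min/kg, the lower of the two numbers; compound 1 at 1040 mL/min/kg sits well above it, a gap beyond the scatter. Within the data shown here, the two compounds differ in more than one place, so no single structural step connects them and the gap cannot be assigned to either change.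

Compound 3 `C=CC(=O)N1CC[C@H](N2C(=O)N(c3ccccc3)Cc3cnc(Nc4ccc(N5CCN(C)CC5)cc4OC)nc32)C1` is compound 2 with one change: methoxy in place of hydrogen on an aromatic carbon. Compound 1 carries the same methoxy and shows the higher number, but its other difference leaves the contribution of the methoxy open. Given the value of compound 1 at 1040 mL/min/kg, the expectation is a step of a 1.7-fold higher number from compound 2 to compound 3 (0.24 log units; within the scatter) of modest size toward faster removal, not confidently beyond the scatter. Compound 3 is estimated at 350 mL/min/kg, with a range from 150 mL/min/kg to 800 mL/min/kg.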

Compound 3, clearance: 200 mL/min/kg
Estimate against measurement, compound 3: 1.8-fold (0.24 log units) above; measured number inside the range.
By their numbers in this assay, from the lowest: compounds 3 and 2 (each within the scatter of the next); then compound 1.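

In this assay methoxy in place of hydrogen on an aromatic carbon, ortho to a large group and meta to a 4-methylpiperazin-1-yl group, gives a 1.0-fold lower number from compound 2 to compound 3 (0.01 log units; within the scatter) and so shows no readable difference at this position when phenyl sits on the amide-type nitrogen. With the methoxy present on both sides, phenyl in place of benzyl on that nitrogen gives a 5.2-fold lower number from compound 1 to compound 3 (0.72 log units; beyond the scatter) and so accounts for a gap that could not be assigned from the earlier pair alone. Nothing available gives a reason for either step.

From the compounds shown here alone, whether the methoxy stays as silent with benzyl on the amide-type nitrogen remains open. Also open, going by these compounds, is how clearance responds to other groups on this aromatic carbon, such as an amine, a fluorine atom or a longer ether chain.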